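Metabolic stability of a stereo variant of compound 1

The source may hold more compounds than are shown below. What is called first, only, known or untested is meant among the compounds shown, and "the series" means these compounds.

Values so far in an ADME assay on microsomes from liver (Rattus norvegicus) for metabolic stability, with a stated time of 10 min (a higher number here means that more of the compound is left, a lower number that less of the compound is left), are these
- Compound 1 `COc1ccccc1-n1nc([C@H]2C[C@@H](C)O[C@@H](C)C2)cc1-c1ccc(Cl)cc1` gives 18% here
- Compound 2 `COCCCc1cc(-c2ccc(Cl)cc2)n(-c2ccccc2OC)n1` gives 4% here

Compound 1 stands highest of the two numbers. Compound 3 `COc1ccccc1-n1nc(C2C[C@H](C)O[C@@H](C)C2)cc1-c1ccc(Cl)cc1` has the same atoms and bonds as compound 1 and differs only in how its stereo elements are drawn (the two compounds have the same atoms and bonds; at least one stereo element is drawn with a configuration in one of them and without one in the other: 2 of 3 stereo elements differ; a stereocentre at a saturated ring carbon is drawn r in compound 1 and without a configuration in compound 3; a stereocentre at a saturated ring carbon is drawn R in compound 1 and S in compound 3). Among the measured compounds shown here, the one measured step (a number 14 percentage points lower from compound 1 to compound 2 (beyond the scatter)) exchanges a whole group, 3-methoxypropyl in place of 2,6-dimethyloxan-4-yl, so it bears only loosely on this change. For the measured compounds named here, no measured pair tests stereochemistry, so no step beyond the scatter is expected in this assay. The estimated step is (no change at the digits printed from compound 1 to compound 3 (within the scatter)). Compound 3 is expected to give 18% (estimated range 8% to 30%).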

Compound 3, percent of the compound remaining: 14%
Compound 3: middle estimate off by 4 percentage points, on the high side, within the range that was stated.
By their numbers in this assay, from the lowest: compounds 2, 3 and 1 (each within the scatter of the next, the first and the last beyond it).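

Changing the drawn stereo elements at the 2,6-dimethyloxan-4-yl group gives a number 4 percentage points lower from compound 1 to compound 3 (within the scatter) in this assay, so this change does not separate the two compounds. Exchanging that group for 3-methoxypropyl now gives a number 10 percentage points higher from compound 2 to compound 3 (within the scatter), although the same exchange starting from compound 1 lay beyond the scatter. The stereo comparison remains only partial: the fact that one of compounds 1 and 3 is drawn with a defined configuration and the other without, at the place where they differ

The compounds shown leave open how a fully defined stereo partner of compound 1 would behave in this assay. They also leave open how an amine, a carboxylic acid or a longer chain would behave at this position.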